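The source may hold more compounds than are shown below. What is called first, only, known or untested is meant among the compounds shown, and "the series" means these compounds.

Compound 1 `COc1cc(NC(C)CCCNC(=O)NOCc2ccccc2)c2ncccc2c1`: 9000 nM
Compound 2 `COc1cc(NC(C)CCCNC(=O)NC(CO)(CO)CO)c2ncccc2c1`: 24000 nM
Compound 3 `COc1cc(N2C(=O)NCCCC2C)c2ncccc2c1`: > 100000 nM (a limit of the assay, not a number)

All three compounds were tested in a functional assay on MCF7 cells (Homo sapiens); a higher number here means a weaker inhibitor, a lower number a stronger inhibitor. Of the two exact numbers, compound 1 holds the lower one, and so it is the better inhibitor of that pair. Compound 3 gives only a limit (the limit of > 100000 nM in this assay, at which 1 of the 3 values shown sits).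

Compound 4 `COC(=O)NCCCC(C)Nc1cc(OC)cc2cccnc12` has not yet been measured. It differs from compound 1 by methoxy in place of (benzyloxy)amino on a carbonyl carbon. Among the measured compounds shown here, only one measured step bears on this change: a 2.7-fold higher number from compound 1 to compound 2 (0.43 log units; beyond the scatter). In that step, 2-hydroxy-1,1-bis(hydroxymethyl)ethyl replaces benzyloxy on an amide-type nitrogen. The benzyloxy is lost there as well, so a similarly modest rise in the number is expected here, though a single step is thin support. The expected change is a 2.8-fold higher number from compound 1 to compound 4 (0.44 log units; beyond the scatter). For compound 4 the estimated value is 25000 nM, with an expected range of 8000 nM to 80000 nM.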

Compound 4, half-maximal inhibitory concentration: > 100000 nM
Compound 4: a limit, no number (the forecaster's own chance of this, stated with the estimate: 25%); at least 4.0-fold (0.60 log units) between middle value and limit.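

In this assay compound 4 gives > 100000 nM, which is a limit of the assay and not a number, and it joins the other limit value: the limit of > 100000 nM in this assay, at which 2 of the 4 values shown sit. Changing the group on the amide-type nitrogen cost little (a 2.7-fold higher number from compound 1 to compound 2 (0.43 log units; beyond the scatter)), whereas replacing (benzyloxy)amino with methoxy on the carbonyl carbon costs much more (an at least 11-fold higher number from compound 1 to compound 4 (1.04 log units; beyond the scatter)). The polar-looking group of compound 2 therefore does not mark the bottom of this position, since methoxy also falls clearly short of it (an at least 4.1-fold higher number from compound 2 to compound 4 (0.61 log units; beyond the scatter)).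

Methoxy removes both the nitrogen and the benzyl part at once, so which loss matters stays open. A plain amine on the carbonyl carbon, or a benzyloxy group attached there directly, would separate the two.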